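The compounds below may be only part of what the source reports. "The series", "measured", "known", "first", "only" and "open" are said of these compounds alone.

For the measured compounds named here, in an ADME assay on Huh-7 cells (Homo sapiens) for cytotoxicity, read by XTT assay, with a stated time of 3 days, tested at 20 uM (a higher number here means a weaker effect of the compound at the concentration tested, a lower number a stronger effect), compound 2 `Fc1ccc(-c2cc(-c3ccc4cc(F)ccc4n3)nn2-c2ccccc2)cc1` gives 88.3%, the lower of the two numbers known so far, while compound 1 `Fc1ccc2nc(-c3cc(-c4ccccc4)n(-c4ccccc4)n3)ccc2c1` gives 124%. Going by the values given here, the single measured step, a number 35.7 percentage points lower from compound 1 to compound 2 (beyond the scatter), concerns fluoro in place of hydrogen on an aromatic carbon and so does not bear on the change to compound 3 `COc1ccc(-c2cc(-c3ccc4cc(F)ccc4n3)nn2-c2ccccc2)cc1`, which is methoxy in place of fluoro on an aromatic carbon. Among the compounds with values here, no measured step swaps fluoro for methoxy, so the data give no direction; the estimated step is a number 1.7 percentage points higher from compound 2 to compound 3 (within the scatter), within the scatter. Compound 3 is therefore expected to give about 90%, between 65% and 120%.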

Compound 3, a percentage reported as activity, at one concentration (the size of the read-out at that concentration, not a potency): 95.6%
Compound 3: middle estimate off by 5.6 percentage points, on the low side; measured number inside the range.
By their numbers in this assay, from the lowest: compounds 2 and 3 (each within the scatter of the next); then compound 1.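

In this assay, the change from 4-fluorophenyl to 4-methoxyphenyl gives a number 7.3 percentage points higher from compound 2 to compound 3 (within the scatter), so the two groups cannot be told apart at this position. Methoxy in place of hydrogen gives a number 28.4 percentage points lower from compound 1 to compound 3 (beyond the scatter), so methoxy, like fluoro, separates from the unsubstituted ring of compound 1. No evidence here explains why either group differs from hydrogen.

As far as these compounds go, it remains open whether any group at this position would give the same shift, or only some. An amine or a carboxylic acid there could side with hydrogen, with fluoro and methoxy, or with neither.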